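Swapping an Ester Chain for Bromophenyl at Sulfur

A few compounds are considered here, and "the series" means these few. Any claim that something is new, unique, unknown or untested is made for them only; others in the source may bear on it.

Compound 1 `CCCCCSc1nc2ccccc2n1CC(=O)O`: 1240 nM
Compound 2 `CCOC(=O)CCCSc1nc2ccccc2n1CC(=O)O`: 4410 nM

Both were tested in an assay on HEK293 cells for displacement of a labelled ligand from prostaglandin D2 receptor 2 (Homo sapiens); a higher number here means a weaker inhibitor, a lower number a stronger inhibitor. Going by the values given here, compound 2 gives the higher of these two numbers; its only neighbour is compound 1, and a 3.6-fold higher number from compound 1 to compound 2 (0.55 log units; beyond the scatter). That step changed the group three bonds along the chain from a sulfur. Compound 3 `O=C(O)Cn1c(SCc2ccccc2Br)nc2ccccc21` differs from compound 2 at a different place, the saturated chain carbon bound to a sulfur: 2-bromophenyl in place of 2-(ethoxycarbonyl)ethyl on a saturated chain carbon bound to a sulfur. Among the compounds with values here, no measured step touches that position, so the one known step is only a loose guide; it shows that the 2-(ethoxycarbonyl)ethyl chain of compound 2 goes with the higher number, which leaves room for its removal to help. For compound 3 a modest move toward a lower number is expected, a 4.9-fold lower number from compound 2 to compound 3 (0.69 log units; beyond the scatter), with wide uncertainty. The estimate for compound 3 is 900 nM, between 200 nM and 4000 nM.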

Compound 3, half-maximal inhibitory concentration: 580 nM
The estimate for compound 3 lay 1.6-fold (0.19 log units) above the measured number, within the range that was stated.
By their numbers in this assay, from the lowest: compound 3; then compound 1; then compound 2.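

Going by these compounds alone, the saturated chain carbon bound to a sulfur clearly matters in this assay: 2-bromophenyl in place of 2-(ethoxycarbonyl)ethyl gives a 7.6-fold lower number from compound 2 to compound 3 (0.88 log units; beyond the scatter) and so outweighs the single earlier step. Losing the ester cannot be the whole story, since the butyl chain also has no ester, yet 2-bromophenyl in place of butyl still gives a 2.1-fold lower number from compound 1 to compound 3 (0.33 log units; beyond the scatter) (a small step, but beyond the usual scatter). Nothing measured here explains why the number falls with this aromatic ring.

As far as these compounds go, whether the bromine itself contributes remains open, and a plain phenyl or a 2-chlorophenyl group at this place would test that. Also open, from the compounds shown here alone, is how the ring's distance from the sulfur affects the number, which a longer chain carrying the same 2-bromophenyl group would address.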